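A few compounds are considered here, and "the series" means these few. Any claim that something is new, unique, unknown or untested is made for them only; others in the source may bear on it.

Compound 1 `COc1ccc(-c2ccccc2)cc1` gives 17 ug/mL in an ADME assay on HEK293 cells (Homo sapiens) for cytotoxicity, read by MTT assay, with a stated time of 3 days; on this read-out higher numbers stand for weaker inhibition and lower numbers for stronger inhibition. Compound 2 `COc1ccc(-c2cccc(O)c2)cc1` gives 14.6 ug/mL in this assay, and compound 3 `COc1ccc(-c2ccccc2)cc1OC` gives 26 ug/mL in this assay. The change hydroxy in place of hydrogen on an aromatic carbon produced a 1.2-fold lower number from compound 1 to compound 2 (0.07 log units; within the scatter). The change methoxy in place of hydrogen on an aromatic carbon produced a 1.5-fold higher number from compound 1 to compound 3 (0.18 log units; within the scatter). Compound 4 `COc1ccc(-c2ccc(O)cc2)cc1OC` has not yet been measured. It differs from compound 3 by hydroxy in place of hydrogen on an aromatic carbon, the same kind of change as hydroxy in place of hydrogen on an aromatic carbon, though here the new group sits para to a large group rather than meta to a group of 8 heavy atoms; the two cores differ by methoxy in place of hydrogen on an aromatic carbon. Compound 4 is expected to show a 1.2-fold lower number from compound 3 to compound 4 (0.07 log units; within the scatter), because the matching step a 1.2-fold lower number from compound 1 to compound 2 (0.07 log units; within the scatter) stayed within the scatter. The estimate for compound 4 in this assay is 22 ug/mL, expected to lie between 13 ug/mL and 38 ug/mL.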

Compound 4, half-maximal inhibitory concentration: > 100 ug/mL
Compound 4: a limit, no number (the forecaster's own chance of this, stated with the estimate: 5%); middle value at least 4.5-fold (0.65 log units) away from the limit.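

In this assay, hydroxy in place of hydrogen on an aromatic carbon gave an at least 3.8-fold higher number from compound 3 to compound 4 (0.58 log units; beyond the scatter), so the earlier step did not carry over from the core of compound 1 to the core of compound 3: the same change on two cores in this assay, a 1.2-fold lower number (0.07 log units; within the scatter) from compound 1 to compound 2 and an at least 3.8-fold higher number (0.58 log units; beyond the scatter) from compound 3 to compound 4, at least 4.4-fold (0.65 log units) apart, beyond the scatter of two such steps

For compound 4 the result is a limit of the assay and not a number: the limit of > 100 ug/mL in this assay, at which 1 of the 4 values shown sits.

These two steps do not show whether the difference goes with the extra methoxy of the core of compound 3 or with the hydroxy lying para to a large group, and they give no rule for other cores.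

The compounds shown leave open whether hydroxy para to a large group on the core of compound 1 would give a similar result. They also leave open whether an amine or a carboxylic acid in that place on the core of compound 3 would match hydroxy.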